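Ester-to-acid change in two dichlorophenyl and chlorobenzyl acrylates

This account rests on a few compounds, and the source may have more. Where it says the series, first, only, none or still open, it means among the compounds named here.

Measured so far:
- compound 1 `C=C(C(=O)OCC)C(O)c1ccc(Cl)cc1Cl`: 68.3 uM
- compound 2 `C=C(C(=O)O)C(O)c1ccc(Cl)cc1Cl`: > 100 uM
- compound 3 `C=C(Cc1ccccc1Cl)C(=O)OCC`: > 100 uM

The series is followed in an ADME assay on THP-1 cells (Homo sapiens) for cytotoxicity, read by MTT assay, with a stated time of 72 h; on this read-out lower numbers stand for higher toxicity in this test and higher numbers for lower toxicity in this test. Compound 1 gives 68.3 uM in this assay. Compound 2 reaches only a limit of this assay, > 100 uM, and no number. The change from compound 1 to compound 2 is hydrogen in place of ethyl on an oxygen next to a carbonyl group, and the step it made is an at least 1.4-fold higher number from compound 1 to compound 2 (0.16 log units; that floor lies within the scatter). Compound 3, which carries a different core, also reaches only a limit of this assay, > 100 uM. How the core of compound 3 differs from that of compound 1 is not broken down here. Of the three values shown, two sit at the limit of > 100 uM in this assay, at which 2 of the 3 values shown sit.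

Compound 4 `C=C(Cc1ccccc1Cl)C(=O)O` is not yet measured. Its difference from compound 3 is hydrogen in place of ethyl on an oxygen next to a carbonyl group, the same change in the same place as that between compound 1 and compound 2. Compound 3 already gives only a limit in this assay, and the earlier step of an at least 1.4-fold higher number from compound 1 to compound 2 (0.16 log units; that floor lies within the scatter) went toward a higher number, so compound 4 is expected to remain at or beyond the limit rather than fall below it. The expected step in this assay is a step that the limit leaves unreadable from compound 3 to compound 4, resting on the direction of an at least 1.4-fold higher number from compound 1 to compound 2 (0.16 log units; that floor lies within the scatter). Compound 4 is expected to give about 150 uM in this assay, between 70 uM and 400 uM, most likely reported as a limit rather than a number.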

Compound 4, half-maximal toxic concentration: > 100 uM
Compound 4: a limit, no number; the forecaster's own chance of this, stated with the estimate: 85%; the middle value is on the limit's open side.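

Compound 3 and compound 4 both end at a limit and give no number, so the change of ethyl to hydrogen between them cannot be read as a step: the limit of > 100 uM in this assay, at which 3 of the 4 values shown sit.

The compounds shown leave open how far beyond that limit compound 2, compound 3 and compound 4 lie, and whether this change moves the read-out at all on the core of compound 3.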